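The source may report more compounds than this note shows. Statements on the series, on what has been measured and on what is new or still open speak of the compounds shown alone.

Three compounds have been measured in an assay on MDA-MB-231 cells for binding affinity to C-X-C chemokine receptor type 4 (Homo sapiens), read by immunofluorescence and microscopy, with stated times of 10 min and 30 min; on this read-out higher numbers stand for an effect only at larger amounts of compound and lower numbers for an effect already at smaller amounts:

compound 1, `Cc1ccc(S(=O)(=O)NCc2ccc(CNC(=O)c3ccc([N+](=O)[O-])cc3)cc2)cc1`, gives 10 nM
compound 2, `COc1ccccc1C(=O)NCc1ccc(CNS(=O)(=O)c2ccc(C)cc2)cc1`, gives 100 nM
compound 3, `Cc1ccc(S(=O)(=O)NCc2ccc(CNC(=O)c3ccc(F)cc3)cc2)cc1`, gives 1 nM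

Compound 3 stands lowest of the three in this assay; its nearest neighbour is compound 1, seen in a 10-fold lower number from compound 1 to compound 3 (1.00 log units; beyond the scatter), and its furthest is compound 2, seen in a 100-fold lower number from compound 2 to compound 3 (2.00 log units; beyond the scatter). Both of these steps lie beyond the scatter, and both change only the group on the carbonyl carbon, so that position clearly matters in this assay.

Compound 4, `Cc1ccc(S(=O)(=O)NCc2ccc(CNC(=O)c3cccnc3)cc2)cc1`, has not yet been measured. It differs from compound 3 as follows: pyridin-3-yl in place of 4-fluorophenyl on a carbonyl carbon. For the measured compounds named here, no measured step replaces the 4-fluorophenyl with a hetero-aromatic ring, so there is no direct precedent; the two steps that touch this carbonyl carbon were modest and large, and every change at this place so far has moved the number beyond the scatter. The author therefore expects compound 4 to give a higher number than compound 3, by a step of about a 10-fold higher number from compound 3 to compound 4 (1.00 log units; beyond the scatter). On that basis compound 4 is estimated at 10 nM, with a range from 2 nM to 50 nM.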

Compound 4, effective concentration (reported as EC, without a stated level of effect): > 1000 nM
Compound 4: a limit, no number (the forecaster's own chance of this, stated with the estimate: 5%); middle value at least 100-fold (2.00 log units) from the limit.
By their numbers in this assay, from the lowest: compound 3; then compound 1; then compound 2. At a limit, above all of these: compound 4.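

In this assay compound 4 reaches only a limit of the assay, not a number: the limit of > 1000 nM in this assay, at which 1 of the 4 values shown sits. The three earlier groups on this carbonyl carbon, each with an aromatic ring of carbon only, all gave numbers, whereas pyridin-3-yl in place of 4-fluorophenyl gives an at least 1000-fold higher number from compound 3 to compound 4 (3.00 log units; beyond the scatter). For the compounds shown here, the change to pyridin-3-yl also stands beyond the scatter against the other two groups, with an at least 100-fold higher number from compound 1 to compound 4 (2.00 log units; beyond the scatter) and an at least 10-fold higher number from compound 2 to compound 4 (1.00 log units; beyond the scatter), so this position can lose far more than the earlier steps showed.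

The compounds shown leave open whether the ring nitrogen or the loss of the fluoro group carries this step, which a phenyl on the same carbonyl carbon would separate. A pyridin-4-yl there would show whether the place of the ring nitrogen matters.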